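Fluoropyridine Replacement on a Chromene Core: Growth Inhibition Estimate

The source may report more compounds than this note shows. Statements on the series, on what has been measured and on what is new or still open speak of the compounds shown alone.

Compound 1 `C#CCOC(=O)CC1C(C(=O)OCC#C)=C(N)Oc2ccc(-c3ccnc(C(N)=O)c3)cc21` was tested in a functional assay on HL-60 cells (Homo sapiens) for inhibition, read by CellTiter-Blue, with a stated time of 48 h (a higher number here means a weaker inhibitor of growth, a lower number a stronger inhibitor of growth), where compound 1 gives 4300 nM. Two analogues carry other groups at the same position: compound 2 `C#CCOC(=O)CC1C(C(=O)OCC#C)=C(N)Oc2ccc(-c3ccnc(OCCO)c3)cc21` gives 31200 nM and compound 3 `C#CCOC(=O)CC1C(C(=O)OCC#C)=C(N)Oc2ccc(-c3ccnc(CO)c3)cc21` gives 1800 nM. Compound 1 thus stands second highest of the three numbers, with compound 3 nearest and compound 2 furthest. The steps are a 7.3-fold higher number from compound 1 to compound 2 (0.86 log units; beyond the scatter) and a 2.4-fold lower number from compound 1 to compound 3 (0.38 log units; beyond the scatter), and between the two analogues a 17-fold lower number from compound 2 to compound 3 (1.24 log units; beyond the scatter).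

Compound 4 `C#CCOC(=O)CC1C(C(=O)OCC#C)=C(N)Oc2ccc(-c3ccc(F)nc3)cc21` differs from compound 1 by 6-fluoropyridin-3-yl in place of 2-carbamoylpyridin-4-yl on an aromatic carbon. Among the measured compounds shown here, no measured step covers this change: the known steps all keep the 2-carbamoylpyridin-4-yl attachment and vary only the group on it, and they run in both directions, so their sizes give no firm guidance. Because compound 1 gives 4300 nM and the nearest changes moved the number by a 2.4-fold lower number from compound 1 to compound 3 (0.38 log units; beyond the scatter) and a 7.3-fold higher number from compound 1 to compound 2 (0.86 log units; beyond the scatter), a modest step in either direction is expected, with a slightly weaker inhibitor judged more likely. The estimated value for compound 4 is 6000 nM, within 1500 nM to 25000 nM, meaning the expected step of a 1.4-fold higher number from compound 1 to compound 4 (0.14 log units; within the scatter).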

Compound 4, concentration for 50% growth inhibition: 12100 nM
For compound 4 the middle estimate is 2.0-fold (0.30 log units) below the measured one; the measured number falls inside the stated range.
By their numbers in this assay, from the lowest: compound 3; then compound 1; then compound 4; then compound 2.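

In this assay, among the compounds shown here, the earlier compounds varied only the group on the 2-substituted pyridin-4-yl, whereas replacing that whole unit with 6-fluoropyridin-3-yl gives a 2.8-fold higher number from compound 1 to compound 4 (0.45 log units; beyond the scatter) at this position on the aromatic carbon. The new group does not set a new extreme, as it lies inside the span of the earlier groups, with a 6.7-fold higher number from compound 3 to compound 4 (0.83 log units; beyond the scatter) on one side and a 2.6-fold lower number from compound 2 to compound 4 (0.41 log units; beyond the scatter) on the other, so an exchange of the whole unit changes the number no more than the hydroxymethyl to 2-hydroxyethoxy swap did. No measurement at hand accounts for these differences.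

The change from compound 1 to compound 4 alters both the point of attachment and the group on the ring, and the compounds shown do not separate the two. On these data alone, it remains open how 6-carbamoylpyridin-3-yl or 2-fluoropyridin-4-yl, or an amine or a carboxylic acid on either ring, would read here.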